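The source may hold more compounds than are shown below. What is called first, only, known or untested is meant among the compounds shown, and "the series" means these compounds.

Measured so far:
compound 1, `N#C/C=C/c1ccc(-c2cnc(C(=O)CCCCCCc3ccccc3)o2)nc1`, 2.1 nM
compound 2, `CSC(=O)CCCCc1cnc(C(=O)CCCCCCc2ccccc2)o1`, 1.8 nM

Both were tested in an assay for inhibition of Fatty-acid amide hydrolase 1 (Rattus norvegicus), using a Dixon plot; a higher number here means a weaker inhibitor, a lower number a stronger inhibitor. Compound 2 and compound 1 give numbers that lie within the usual scatter of each other, so the two cannot be told apart on these data; compound 2 simply stands alongside compound 1 among the strong inhibitors. Among the compounds with values here, no pair differing in one place has been measured, so no step has been read directly.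

Compound 3, `CSCCCCCc1cnc(C(=O)CCCCCCc2ccccc2)o1`, is not yet measured. It differs from compound 2 in one place: (methylsulfanyl)methyl in place of (methylsulfanyl)carbonyl on a saturated chain carbon, four bonds along the chain from an aromatic carbon. A carbonyl is lost on the chain, and the group becomes one heavy atom shorter with one fewer hydrogen-bond acceptor.

Within the data shown here, with no measured step to lean on, the expectation for compound 3 in this assay rests on the value of compound 2, 1.8 nM, and a change this small on a flexible chain is expected to move the number only a little, if at all, toward a somewhat weaker inhibitor. Compound 3 is therefore estimated at 4 nM, with a range from 1.5 nM to 12 nM, a step of a 2.2-fold higher number from compound 2 to compound 3 (0.35 log units; beyond the scatter).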

Compound 3, inhibition constant: 8.1 nM
For compound 3 the middle estimate is 2.0-fold (0.31 log units) below the measured one; the measured number falls inside the stated range.
By their numbers in this assay, from the lowest: compounds 2 and 1 (each within the scatter of the next); then compound 3.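

In this assay, within the data shown here, this is the first direct reading at this place, on a saturated chain carbon, four bonds along the chain from an aromatic carbon. Replacing (methylsulfanyl)carbonyl with (methylsulfanyl)methyl gives a 4.5-fold higher number from compound 2 to compound 3 (0.65 log units; beyond the scatter) and so shows that the chain end is not indifferent to this change, though the loss is modest and compound 3 at 8.1 nM remains a measurable inhibitor. No available measurement gives a reason for this step.

The compounds shown leave open whether other groups at this chain end, such as a methyl ester, an amide or a carboxylic acid, would match the (methylsulfanyl)carbonyl of compound 2. They also leave open how a shorter or longer chain carrying the same group would read.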